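From cyano to fluoro: a cytotoxicity estimate for compound 4

This account rests on a few compounds, and the source may have more. Where it says the series, first, only, none or still open, it means among the compounds named here.

Compound 3 `N#Cc1ccc(NC(=S)OCCc2ccccn2)cc1` gives 45000 nM in an ADME assay on MT4 cells (Homo sapiens) for cytotoxicity, read by MTT assay; a lower number here means that less compound is tolerated, a higher number that more compound is tolerated. Compound 2 `CC(C)c1ccc(NC(=S)OCCc2ccccn2)cc1` gives 45000 nM in this assay, and there is no change at the digits printed from compound 2 to compound 3 (within the scatter). For compound 1 `S=C(Nc1ccccc1)OCCc1ccccn1` this assay reports only a limit, > 100000 nM. From that limit there is an at least 2.2-fold lower number from compound 1 to compound 2 (0.34 log units; beyond the scatter) and likewise an at least 2.2-fold lower number from compound 1 to compound 3 (0.34 log units; beyond the scatter). Compound 3 thus stands level with compound 2, and both sit apart from the limit recorded for compound 1.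

Compound 4 `Fc1ccc(NC(=S)OCCc2ccccn2)cc1` differs from compound 3 in one place: fluoro in place of cyano on an aromatic carbon. Within the data shown here, two measured steps bear on this. The first is the arrival of cyano, an at least 2.2-fold lower number from compound 1 to compound 3 (0.34 log units; beyond the scatter). The second is the exchange of one substituent for another at the same carbon, no change at the digits printed from compound 2 to compound 3 (within the scatter), which shows that isopropyl and cyano gave the same reading. Taking cyano away again in favour of a group of one heavy atom may partly unwind the first step. The step from compound 3 to compound 4 is therefore expected to be modest and toward a higher number, a 1.3-fold higher number from compound 3 to compound 4 (0.12 log units; within the scatter). Compound 4 is estimated at 60000 nM, expected to fall between 30000 nM and 120000 nM.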

Compound 4, half-maximal cytotoxic concentration: > 100000 nM
Compound 4: no number, only a limit (the forecaster's own chance of this, stated with the estimate: 35%); middle value at least 1.6-fold (0.22 log units) away from the limit.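

At this carbon, para to a large group, the new compound separates substituents that had looked alike: an at least 2.2-fold higher number from compound 3 to compound 4 (0.34 log units; beyond the scatter), and an at least 2.2-fold higher number from compound 2 to compound 4 (0.34 log units; beyond the scatter), whereas cyano and isopropyl had given the same reading. In this assay compound 4 gives no number, only a limit, > 100000 nM. Among the compounds shown, fluoro therefore sides with the hydrogen of compound 1 and not with cyano or isopropyl, while the step from compound 1 to compound 4 cannot be read, since it joins two limits: the limit of > 100000 nM in this assay, at which 2 of the 4 values shown sit.

On these data alone, how compound 1 and compound 4 would stand against each other as true numbers remains open. So does whether an amine, a carboxylic acid or a longer chain at this carbon would read with cyano and isopropyl or with fluoro and hydrogen.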